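Three close values, and a nitro compound to come

The source may report more compounds than this note shows. Statements on the series, on what has been measured and on what is new or still open speak of the compounds shown alone.

compound 1 `O=C1c2ccccc2C(=O)N1CCOC(=S)N(C(=O)c1cccc(F)c1F)c1ccc(Cl)cc1` gives 58000 nM
compound 2 `O=C1c2ccccc2C(=O)N1CCOC(=S)N(C(=O)c1ccc(F)cc1F)c1ccc(Cl)cc1` gives 52000 nM
compound 3 `O=C1c2ccccc2C(=O)N1CCOC(=S)N(C(=O)c1cc(Cl)cc(Cl)c1)c1ccc(Cl)cc1` gives 32000 nM

These values come from an ADME assay on MT4 cells (Homo sapiens) for cytotoxicity, read by MTT assay (on this read-out lower numbers stand for higher toxicity in this test and higher numbers for lower toxicity in this test), and the three compounds differ only in the substituted phenyl on a carbonyl carbon. Compound 3 cannot be told apart from the other two on these numbers. The data show a 1.8-fold lower number from compound 1 to compound 3 (0.26 log units; within the scatter) and also a 1.6-fold lower number from compound 2 to compound 3 (0.21 log units; within the scatter) so its place among them carries no real order.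

The next compound is compound 4 `O=C1c2ccccc2C(=O)N1CCOC(=S)N(C(=O)c1ccc([N+](=O)[O-])cc1Cl)c1ccc(Cl)cc1` with 2-chloro-4-nitrophenyl in place of 3,5-dichlorophenyl on a carbonyl carbon.

The measured steps that bear on this change are swaps of that same group. Besides the two above, there is a 1.1-fold lower number from compound 1 to compound 2 (0.05 log units; within the scatter) and this one also stays inside the scatter. None of these swaps brings in a nitro group, so the data cannot show what this one will do. Since all three swaps stayed small, no step beyond the scatter is expected in this assay and no direction is favoured. The expected step is therefore small: a 1.3-fold higher number from compound 3 to compound 4 (0.10 log units; within the scatter) by estimate. For compound 4 the estimated value is 40000 nM (expected range 18000 nM to 90000 nM).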

Compound 4, half-maximal cytotoxic concentration: 19000 nM
The estimate for compound 4 lay 2.1-fold (0.32 log units) above the measured number; measured number inside the range.
By their numbers in this assay, from the lowest: compounds 4, 3, 2 and 1 (each within the scatter of the next, the first and the last beyond it).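

In this assay this place on the carbonyl carbon now gives its first steps beyond the scatter: the 2-chloro-4-nitrophenyl group brings a 2.7-fold lower number from compound 2 to compound 4 (0.44 log units; beyond the scatter) and also a 3.1-fold lower number from compound 1 to compound 4 (0.48 log units; beyond the scatter), both modest in size. Measured against the 3,5-dichlorophenyl group the same kind of swap stays inside the scatter, with a 1.7-fold lower number from compound 3 to compound 4 (0.23 log units; within the scatter), so compound 4 separates only from the two difluorophenyl compounds and cannot be told apart from compound 3. Nothing measured here gives a reason for these steps.

The compounds shown leave open whether the nitro group or the chlorine of the new group goes with the lower number, as compound 4 is the only one carrying a nitro group and it also carries a chlorine on the same ring. Also open, going by these compounds, is how this read-out would respond to a phenyl ring bearing an amine or a carboxylic acid, and whether the modest steps seen here would hold with such groups on the same carbonyl carbon.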